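Hydroxy for nitro on the phenol ring of the hydrazone

A few compounds are considered here, and "the series" means these few. Any claim that something is new, unique, unknown or untested is made for them only; others in the source may bear on it.

Among the measured compounds shown here, compound 1 `O=[N+]([O-])c1ccc(O)c(/C=N/Nc2nc3ccccc3s2)c1` is the only compound of the pair with a numbered result: in a functional assay on HL-60 cells (Homo sapiens) for cytotoxicity, read by MTT assay, with a stated time of 72 h (on this read-out higher numbers stand for weaker inhibition and lower numbers for stronger inhibition), compound 1 gives 1650 nM. Compound 2 `COc1ccc(/C=N/Nc2nc3ccccc3s2)c(OC)c1` reaches only a limit of this assay, > 15900 nM, so it is not a number and the comparison the limit of > 15900 nM in this assay, at which 1 of the 2 values shown sits, rests on compound 1 alone. Compound 3 `Oc1ccc(O)c(/C=N/Nc2nc3ccccc3s2)c1` carries the change (hydroxy in place of nitro on an aromatic carbon). No measured step of this kind is shown, so the direction is open; a modest loss beyond the scatter is expected, a 2.1-fold higher number from compound 1 to compound 3 (0.33 log units; beyond the scatter). Compound 3 is estimated at 3500 nM, between 900 nM and 14000 nM.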

Compound 3, half-maximal inhibitory concentration: 590 nM
The estimate for compound 3 lay 5.9-fold (0.77 log units) above the measured number, and the stated range ends above it.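

In this assay, replacing nitro with hydroxy on this aromatic carbon, para to a hydroxy group, gives a 2.8-fold lower number from compound 1 to compound 3 (0.45 log units; beyond the scatter). The nitro group is therefore not required at this place for activity in this assay, and the smaller hydroxy group is accepted in its stead. Nothing measured here bears on the cause of this gain. Open, on these data alone, is whether an amine or a carboxylic acid at this place would keep the gain. Also open, as far as these compounds go, is whether the same change would act alike on another core.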